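From 3-Fluorophenyl to 2,5-Difluorophenyl: an Expected Activity

The source may hold more compounds than are shown below. What is called first, only, known or untested is meant among the compounds shown, and "the series" means these compounds.

Measured so far in a functional assay on CHO cells with adenosine receptor A1 (Homo sapiens) as the target, read by cAMP accumulation and immunoassay, with a stated time of 6 min, tested at 0.01 uM; a lower number here means a stronger effect, a higher number a weaker effect of the compound at the concentration tested:
compound 1 `Nc1scc(CN2CCN(c3cccc(C(F)(F)F)c3)CC2)c1C(=O)c1ccc(Cl)cc1` gives -8.2%
compound 2 `Nc1scc(CN2CCN(c3cccc(F)c3)CC2)c1C(=O)c1ccc(Cl)cc1` gives -18%

Compound 2 carries the lower of the two numbers, yet the step of a number 9.8 percentage points lower from compound 1 to compound 2 (within the scatter) lies within the scatter, so the two compounds cannot be ranked. Compound 3 `Nc1scc(CN2CCN(c3cc(F)ccc3F)CC2)c1C(=O)c1ccc(Cl)cc1` differs from compound 2 by fluoro in place of hydrogen on an aromatic carbon. Among the measured compounds shown here, the only measured step, fluoro in place of trifluoromethyl, moved the read-out within the scatter, and no measured step adds a fluoro to the phenyl. Compound 3 is therefore expected to show a number 3 percentage points higher from compound 2 to compound 3 (within the scatter), nothing beyond the scatter. The estimate for compound 3 in this assay is -15%, between -35% and 5%.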

Compound 3, a percentage reported as activity, at one concentration (the size of the read-out at that concentration, not a potency): 3.1%
Estimate against measurement, compound 3: 18.1 percentage points below; low and high end bracket the measured number.
By their numbers in this assay, from the lowest: compounds 2 and 1 (each within the scatter of the next); then compound 3.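

In this assay, among the compounds shown here, fluoro in place of hydrogen on an aromatic carbon, ortho to a large group and para to a fluoro group, gives the first step on this phenyl beyond the scatter, with a number 21.1 percentage points higher from compound 2 to compound 3 (beyond the scatter) and thus a modestly weaker effect at the concentration tested. The 2,5-difluorophenyl also separates from the 3-(trifluoromethyl)phenyl, with a number 11.3 percentage points higher from compound 1 to compound 3 (beyond the scatter) as a modest step in the same direction. Nothing at hand gives a reason for this shift.

From the compounds shown here alone, whether the new fluoro acts alone or only with the fluoro para to it stays open. So does what a chlorine, a methyl or a methoxy would give on the same aromatic carbon.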